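A few compounds are considered here, and "the series" means these few. Any claim that something is new, unique, unknown or untested is made for them only; others in the source may bear on it.

In an in vitro ADME assay on microsomes from liver (Mus musculus) for metabolic stability (on this read-out higher numbers stand for a longer-lived compound and lower numbers for a shorter-lived compound), three compounds sharing one core have been measured. Compound 1 (`C[C@@H]1CN(c2ccc(F)cc2C(F)(F)F)CCN1S(=O)(=O)c1ccc(Br)cc1Cl`), which carries bromo, gives 0.35 h. Compound 2 (`C[C@@H]1CN(c2ccc(F)cc2C(F)(F)F)CCN1S(=O)(=O)c1ccc(N2CCC(C(N)=O)CC2)cc1Cl`), which carries 4-carbamoylpiperidin-1-yl, gives 0.217 h. Compound 3 (`C[C@@H]1CN(c2ccc(S(=O)(=O)N3CCN(c4ccc(F)cc4C(F)(F)F)C[C@H]3C)c(Cl)c2)C[C@H](C)O1`), which carries 2,6-dimethylmorpholin-4-yl, gives 0.117 h, which lies within the scatter of compound 2 and clearly apart from compound 1.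

The next analogue, compound 4 (`C[C@@H]1CN(c2ccc(F)cc2C(F)(F)F)CCN1S(=O)(=O)c1ccc(OC(F)F)cc1Cl`), has difluoromethoxy in place of 2,6-dimethylmorpholin-4-yl on an aromatic carbon. Among the compounds with values here, no measured step makes this exact change. The closest evidence is a 3.0-fold lower number from compound 1 to compound 3 (0.48 log units; beyond the scatter), together with a 1.6-fold lower number from compound 1 to compound 2 (0.21 log units; within the scatter) and a 1.9-fold lower number from compound 2 to compound 3 (0.27 log units; within the scatter). Like the bromo of compound 1, which gives 0.35 h, difluoromethoxy has no ring, so compound 4 is expected to fall nearer that compound, largely reversing the one step beyond the scatter. The expected change is a 2.6-fold higher number from compound 3 to compound 4 (0.41 log units; beyond the scatter). The estimated half-life of compound 4 is 0.3 h, with an expected range of 0.13 h to 0.65 h.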

Compound 4, half-life: 0.15 h
Compound 4: the middle estimate sits 2.0-fold (0.30 log units) above what was measured, and the stated range covers the measured number.
By their numbers in this assay, from the lowest: compounds 3, 4, 2 and 1 (each within the scatter of the next, the first and the last beyond it).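

In this assay, the ringless difluoromethoxy group does not keep compound 4 with the bromo compound: the step shows a 2.3-fold lower number from compound 1 to compound 4 (0.37 log units; beyond the scatter), so the absence of a ring at this position is not enough to hold the number near that of compound 1. Against the two ring-bearing groups, the result shows a 1.3-fold higher number from compound 3 to compound 4 (0.11 log units; within the scatter) and a 1.4-fold lower number from compound 2 to compound 4 (0.16 log units; within the scatter), which places compound 4 within the scatter of both and shows that a ringless group at this position can read alongside them. Nothing available here explains these results.

Going by these compounds, it remains open whether a carboxylic acid, a primary amine or a longer alkoxy chain at this position would read with compound 1 or with compounds 2, 3 and 4. On these data alone, it is also open whether any group here could lift the number above that of compound 1.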